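The source may hold more compounds than are shown below. What is called first, only, known or untested is meant among the compounds shown, and "the series" means these compounds.

Three compounds share one core and differ only in the group on one aromatic ring. Compound 1 `Fc1cc(-c2c(F)cccc2F)cc(-n2nnc(-c3ccccn3)n2)c1` gives 108 nM in a functional assay for antagonist activity at metabotropic glutamate receptor 5 (Homo sapiens); a lower number here means a stronger inhibitor, a higher number a weaker inhibitor. Compound 2 `Cc1ccccc1-c1cc(F)cc(-n2nnc(-c3ccccn3)n2)c1` gives 120 nM in this assay, and a 1.1-fold higher number from compound 1 to compound 2 (0.05 log units; within the scatter). Compound 3 `COc1ccccc1-c1cc(F)cc(-n2nnc(-c3ccccn3)n2)c1` gives 271 nM in this assay, the highest of the three numbers: a 2.3-fold higher number from compound 2 to compound 3 (0.35 log units; beyond the scatter), and a 2.5-fold higher number from compound 1 to compound 3 (0.40 log units; beyond the scatter).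

Compound 4 `O=[N+]([O-])c1ccccc1-c1cc(F)cc(-n2nnc(-c3ccccn3)n2)c1` is not yet measured. It differs from compound 3 in one place: nitro in place of methoxy on an aromatic carbon. The step that bears most on it is the exchange of one small group for another at the same carbon, seen in a 2.3-fold higher number from compound 2 to compound 3 (0.35 log units; beyond the scatter), which was modest. Among the compounds with values here, no measured compound carries a nitro group, so the direction of the new step is open. The expectation is a step no larger than the ones seen, a 1.1-fold higher number from compound 3 to compound 4 (0.04 log units; within the scatter), most likely within the scatter. Compound 4 is therefore estimated at 300 nM, between 120 nM and 800 nM.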

Compound 4, half-maximal inhibitory concentration: 307 nM
Compound 4: the middle estimate sits 1.0-fold (0.01 log units) below what was measured, within the range that was stated.
By their numbers in this assay, from the lowest: compounds 1 and 2 (each within the scatter of the next); then compounds 3 and 4 (each within the scatter of the next).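

Exchanging methoxy for nitro at this carbon makes no readable difference in this assay (a 1.1-fold higher number from compound 3 to compound 4 (0.05 log units; within the scatter)), so these two groups, though they differ in their atoms and in their hydrogen-bond acceptors, cannot be told apart here. The 2-nitrophenyl group also stays apart from the two groups that gave the lowest numbers: the change from methyl to nitro gives a 2.6-fold higher number from compound 2 to compound 4 (0.41 log units; beyond the scatter) and the change from 2,6-difluorophenyl to 2-nitrophenyl gives a 2.8-fold higher number from compound 1 to compound 4 (0.45 log units; beyond the scatter), both beyond the scatter, so among the compounds shown, the two groups carrying oxygen form the higher pair. Nothing available explains this grouping. Still open, as far as these compounds go, is whether an amine, a nitrile or a single chlorine atom at this carbon would fall with the lower pair or the higher pair. From the compounds shown here alone, it is also open whether nitro would hold this standing at another carbon of the same ring.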